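Replacing the group on the amine nitrogen of compound 2

A few compounds are considered here, and "the series" means these few. Any claim that something is new, unique, unknown or untested is made for them only; others in the source may bear on it.

Values in a functional assay on PANC-1 cells (Homo sapiens) for inhibition, read by XTT assay, with a stated time of 72 h; a higher number here means a weaker inhibitor, a lower number a stronger inhibitor:
- compound 1 `CCCCCC/C=C/CCCCCCCCOC[C@H]1NC[C@H](O)[C@@H]1O`: 80000 nM
- compound 2 `Cc1ccc([S+]([O-])N2CCC[C@H]2COCCCCCC/C=C/c2ccc(-c3ccccc3)cc2)cc1`: >= 100000 nM (a limit)
- compound 3 `Cc1ccc([S+]([O-])N2CCC[C@H]2COCCCCCC/C=C/c2ccc(Oc3ccccc3)cc2)cc1`: 60000 nM

Compound 2 stands only as a limit, not a number: the limit of >= 100000 nM in this assay, at which 1 of the 3 values shown sits.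

Compound 4 `CC(C)(C)OC(=O)NCC(=O)N1CCC[C@H]1COCCCCCC/C=C/c1ccc(-c2ccccc2)cc1` departs from compound 2 as follows: a group of 11 heavy atoms (7 carbon, 1 nitrogen, 3 oxygen; no ring) in place of a group of 9 heavy atoms (7 carbon, 1 oxygen, 1 sulfur; one six-membered aromatic ring of carbon only), on an amine nitrogen in a ring. The entering group is (((tert-butoxycarbonyl)amino)methyl)carbonyl.

Among the measured compounds shown here, the one measured step, an at least 1.6-fold lower number from compound 2 to compound 3 (0.22 log units; that floor lies within the scatter), lies elsewhere in the molecule, and its floor lies within the scatter, so it bears only loosely on this change. Compound 1 at 80000 nM and compound 3 at 60000 nM suggest that any move in this assay would be toward a lower number, and none beyond the scatter is expected. The expected step is an at least 1.4-fold lower number from compound 2 to compound 4 (0.15 log units; that floor lies within the scatter). Compound 4 is estimated at 70000 nM, with an expected range of 25000 nM to 100000 nM.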

Compound 4, half-maximal inhibitory concentration: 66700 nM
Compound 4: the middle estimate sits 1.0-fold (0.02 log units) above what was measured, and the stated range covers the measured number.
By their numbers in this assay, from the lowest: compounds 3, 4 and 1 (each within the scatter of the next). At a limit, above all of these: compound 2.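

In this assay, the change on the amine nitrogen in a ring gives an at least 1.4-fold lower number from compound 2 to compound 4 (0.17 log units; that floor lies within the scatter). This position therefore accepts a (((tert-butoxycarbonyl)amino)methyl)carbonyl group, which has no ring, and the series still gives a measured number, though no gain beyond the scatter can be claimed. Compound 2 stands as a limit, so the step is a floor and its true size cannot be read: the limit of >= 100000 nM in this assay, at which 1 of the 4 values shown sits.

From the compounds shown here alone, whether a free primary amine or a carboxylic acid in this group would move the number beyond the scatter remains open.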